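Swapping methyl for bromo on the N-aryl ring

A few compounds are considered here, and "the series" means these few. Any claim that something is new, unique, unknown or untested is made for them only; others in the source may bear on it.

Of the compounds shown here, two of one shared core have been measured in a functional assay on NCI-H292 cells (Homo sapiens) for antiproliferative activity; a higher number here means a weaker inhibitor, a lower number a stronger inhibitor. Compound 1, `O=C1N/C(=C\c2ccc(Br)cc2)C(=O)N1c1ccc(Cl)cc1`, gives 46600 nM in this assay. Compound 2, `Cc1ccc(N2C(=O)N/C(=C\c3ccc(O)cc3)C2=O)cc1`, gives 27900 nM in this assay. Compound 2 has the lowest of the two numbers, but its nearest neighbour, compound 1, sits within the usual scatter, so the two cannot be told apart. Compound 3, `O=C1N/C(=C\c2ccc(O)cc2)C(=O)N1c1ccc(Br)cc1`, has not yet been measured. It differs from compound 2 in one place: bromo in place of methyl on an aromatic carbon. Among the measured compounds shown here, no step between two measured compounds isolates this change, so there is nothing to lean on beyond the weak numbers of compound 1 and compound 2. In this assay the step from compound 2 to compound 3 is expected to be a 1.1-fold higher number from compound 2 to compound 3 (0.03 log units; within the scatter), nothing beyond the scatter. Compound 3 is therefore estimated at 30000 nM in this assay, within a range from 12000 nM to 75000 nM.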

Compound 3, half-maximal inhibitory concentration: 69900 nM
For compound 3 the middle estimate is 2.3-fold (0.37 log units) below the measured one, within the range that was stated.
By their numbers in this assay, from the lowest: compounds 2, 1 and 3 (each within the scatter of the next, the first and the last beyond it).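

Among the compounds shown here, exchanging 4-methylphenyl for 4-bromophenyl with the rest of the molecule unchanged gives a 2.5-fold higher number from compound 2 to compound 3 (0.40 log units; beyond the scatter) in this assay as the first clean reading of this change, showing that this position responds to it, though only modestly. Compound 1 and compound 2 differ in more than one place, so their pair could not show what this single exchange does. No measurement is available that would explain the shift.

A single pair cannot tell whether bromo in place of methyl would have the same effect with a different substituent elsewhere on the shared core. As far as these compounds go, how an amine, a methoxy group or a carboxylic acid at this position would compare with methyl and bromo also remains open.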